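Cytotoxicity notes: from compound 3 to compound 4

A few compounds are considered here, and "the series" means these few. Any claim that something is new, unique, unknown or untested is made for them only; others in the source may bear on it.

Compound 1 `CCCOc1ccc(CN(Cc2ccc(C(C)(C)C)cc2)Cc2cc3cc(C)ccc3[nH]c2=O)cc1` and compound 2 `CSc1ccc(CN(Cc2ccc(C(C)(C)C)cc2)Cc2cc3cc(C)ccc3[nH]c2=O)cc1` share their core with compound 3 `Cc1ccc2[nH]c(=O)c(CN(Cc3ccc(C(C)(C)C)cc3)[C@H](CO)c3ccccc3)cc2c1`. In a toxicity assay on MDCK cells (Canis lupus familiaris) for cytotoxicity, read by crystal violet staining, with a stated time of 48 h (on this read-out lower numbers stand for higher toxicity in this test and higher numbers for lower toxicity in this test), compound 1 reaches only a limit, > 5000 nM. In this assay compound 2 likewise stops at a limit, > 5000 nM. Compound 3 also gives only a limit in this assay, > 10000 nM. Hence a step that the two limits leave unreadable from compound 1 to compound 2, a step that the two limits leave unreadable from compound 1 to compound 3 and a step that the two limits leave unreadable from compound 2 to compound 3. All that is known is the limit of > 5000 nM in this assay, at which 2 of the 3 values shown sit, and (the limit of > 10000 nM in this assay, at which 1 of the 3 values shown sits). Compound 4 `Cc1ccc2[nH]c(=O)c(CN(Cc3ccc(C(C)(C)C)cc3)C(C)c3ccc(N(C)C)c(Cl)c3)cc2c1` carries 1-(3-chloro-4-(dimethylamino)phenyl)ethyl in place of 2-hydroxy-1-phenylethyl on an amine nitrogen. Going by the values given here, no measured step reads on this change, so no step beyond the scatter is foreseen in this assay. Compound 4 is expected to sit near the limits again, an expected step that the limit leaves unreadable from compound 3 to compound 4. Compound 4 is therefore estimated at 15000 nM, within 5000 nM to 50000 nM.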

Compound 4, half-maximal cytotoxic concentration: 9800 nM
Compound 4: the middle estimate sits 1.5-fold (0.18 log units) above what was measured; low and high end bracket the measured number.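

In this assay, going by these compounds alone, compound 4 gives 9800 nM as the first number rather than a limit, with 1-(3-chloro-4-(dimethylamino)phenyl)ethyl on the amine nitrogen. The change reads as an at least 1.0-fold lower number from compound 3 to compound 4 (0.00 log units; that floor lies within the scatter) and so establishes no shift in toxicity, while the steps from compound 1 and compound 2 to compound 4 cannot be read. Compound 3 remains a limit: the limit of > 10000 nM in this assay, at which 1 of the 4 values shown sits.

The compounds shown do not separate the chloro group from the dimethylamino group within the entering substituent. Going by these compounds, how a carboxylic acid on that aromatic ring would read remains open.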